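Shifting One Methoxy Group: What Compound 3 Might Show

This account rests on a few compounds, and the source may have more. Where it says the series, first, only, none or still open, it means among the compounds named here.

Of the compounds shown here, two from this study have already been tested in a functional assay on PC-3 cells (Homo sapiens) for inhibition, read by sulforhodamine B assay, with a stated time of 48 h, tested at 50 uM; on this read-out higher numbers stand for more inhibition of growth at the one concentration tested and lower numbers for less inhibition of growth. Compound 1, with the structure `COc1cc(/C=C/C(=O)/C=C/c2cccc3ccccc23)ccc1OCc1cn(CCCOc2cc(=O)oc3ccccc23)nn1`, gives 8% in this assay. Compound 2, with the structure `COc1cccc(/C=C/C(=O)/C=C/c2ccc(OCc3cn(CCCCOc4cc(=O)oc5ccccc45)nn3)c(OC)c2)c1`, is reported in this assay as "not active" (no number reported), so no single number stands for it; it sits at the inactive end of what was measured, and with compound 1 also low, the two results together show little growth inhibition anywhere in this small set.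

Compound 3, with the structure `COc1ccc(/C=C/C(=O)/C=C/c2ccc(OCc3cn(CCCCOc4cc(=O)oc5ccccc45)nn3)c(OC)c2)cc1`, has not yet been tested. Its difference from compound 2 is 4-methoxyphenyl in place of 3-methoxyphenyl on a double-bonded chain carbon bound to a double-bonded chain carbon. The two share every atom and differ only in how one methoxy group is placed on its ring.

Among the measured compounds shown here, no pair of measured compounds differing in one place is available, so the size of such a step cannot be read from the data. Given that compound 2 is reported as "not active" (no number reported) and compound 1 gives 8%, the expectation is a change no larger than the scatter, in no clear direction. Compound 3 is therefore expected to give about 10% in this assay, within a range from 0% to 30%.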

Compound 3, percent growth inhibition at one concentration: "not active" (no number reported)
Compound 3 has no reported number here, and the estimate cannot be compared.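

In this assay compound 2 and compound 3 are both reported without a number, so no step can be read between them. No measurement shown here bears on this result. From the compounds shown here alone, whether swapping 3-methoxyphenyl for 4-methoxyphenyl changes growth inhibition at all remains open, with neither compound giving a figure to compare.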